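Propanoyl to isopropylcarbonyl on compound 1

The source may hold more compounds than are shown below. What is called first, only, known or untested is meant among the compounds shown, and "the series" means these compounds.

Measured so far in a functional assay on K562 cells (Homo sapiens) for inhibition (a lower number here means a stronger inhibitor, a higher number a weaker inhibitor), as half-maximal inhibitory concentrations
compound 1 `CCC(=O)OC1C(C(O)CO)OC2OC(C)(C)OC21` gives 2400000 nM
compound 2 `CC(=O)OC1C(C(O)CO)OC2OC(C)(C)OC21` gives 3800000 nM

Within the data shown here, compound 1 has only one measured neighbour, and the two values lie within the scatter of each other, as a 1.6-fold higher number from compound 1 to compound 2 (0.20 log units; within the scatter) shows. Compound 3 `CC(C)C(=O)OC1C(C(O)CO)OC2OC(C)(C)OC21` differs from compound 1 by methyl in place of hydrogen on a saturated chain carbon bound to a carbonyl carbon and a saturated chain carbon in the same chain, which reads further out as propanoyl to isopropylcarbonyl. Among the measured compounds shown here, the one measured step that bears on this change is also a swap between hydrogen and methyl on a saturated chain carbon bound to a carbonyl carbon, and it stays within the scatter. It sets no firm direction, and no data yet exist for this added methyl. No shift beyond the scatter is therefore expected in this assay, and the expected step is a 1.2-fold lower number from compound 1 to compound 3 (0.08 log units; within the scatter) as a working estimate. Compound 3 is estimated at 2000000 nM (expected range 900000 nM to 4500000 nM).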

Compound 3, half-maximal inhibitory concentration: 2500000 nM
Beside the measured number, compound 3's estimate is 1.3-fold (0.10 log units) below it, within the range that was stated.
By their numbers in this assay, from the lowest: compounds 1, 3 and 2 (each within the scatter of the next).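

In this assay, methyl in place of hydrogen on a saturated chain carbon bound to a carbonyl carbon and a saturated chain carbon gives a 1.0-fold higher number from compound 1 to compound 3 (0.02 log units; within the scatter) and thus sets no direction for this added methyl. Isopropyl in place of methyl on a carbonyl carbon gives a 1.5-fold lower number from compound 2 to compound 3 (0.18 log units; within the scatter), so methyl, ethyl and isopropyl on that carbonyl carbon now all read alike, with no listed step among compounds 1, 2 and 3 beyond the scatter. No supporting measurement is available to explain this result.

As far as these compounds go, whether any group on this carbonyl carbon can move the number remains open, including a longer chain, a phenyl ring or an amine. From the compounds shown here alone, the shared core is constant across all three compounds, so its contribution to the reading is also open.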